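Removing one fluorine from the aryl on the core nitrogen

The compounds below may be only part of what the source reports. "The series", "measured", "known", "first", "only" and "open" are said of these compounds alone.

Three compounds sharing one core have been run in an ADME assay on Huh-7 cells (Homo sapiens) for cytotoxicity; on this read-out higher numbers stand for lower toxicity in this test and lower numbers for higher toxicity in this test. Compound 1 `Cc1ccccc1-c1nn(-c2ccc(C(F)(F)F)cc2)cc1CNCCN1CCN(C)CC1` gives 11000 nM. Compound 2 `Cc1ccccc1-c1nn(C(C)C)cc1CNCCN1CCN(C)CC1` reaches only a limit of the assay, > 20000 nM. Compound 3 `Cc1ccccc1-c1nn(-c2ccc(F)c(F)c2)cc1CNCCN1CCN(C)CC1` likewise reaches only a limit, > 20000 nM. Two of the three results therefore sit at the same ceiling, as summarised by the limit of > 20000 nM in this assay, at which 2 of the 3 values shown sit, so compound 3 stands at the least toxic end of what the numbers can show. The measured steps are an at least 1.8-fold higher number from compound 1 to compound 2 (0.25 log units; that floor lies within the scatter) and an at least 1.8-fold higher number from compound 1 to compound 3 (0.25 log units; that floor lies within the scatter), while a step that the two limits leave unreadable from compound 2 to compound 3.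

Compound 4 `Cc1ccccc1-c1nn(-c2ccc(F)cc2)cc1CNCCN1CCN(C)CC1` differs from compound 3 by hydrogen in place of fluoro on an aromatic carbon. Among the compounds with values here, no measured step bears directly on such a small change; the only neighbouring steps, from compound 1, were at or within the scatter. The account therefore expects no step beyond the scatter, a number no higher from compound 3 to compound 4 (the limit leaves the size open), with compound 4 most likely again reported only as a limit. Compound 4 is estimated at 20000 nM, within 8000 nM to 60000 nM.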

Compound 4, half-maximal cytotoxic concentration: > 20000 nM
Compound 4 was reported as a limit (the forecaster's own chance of this, stated with the estimate: 60%); the middle value lies on the limit itself.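

In this assay compound 4 gives > 20000 nM, a limit of the assay, so with hydrogen in place of fluoro on this aromatic carbon the result stays at the limit and the second fluoro group is not needed to reach it. The 4-fluorophenyl group also separates from the 4-(trifluoromethyl)phenyl group, though only weakly, with an at least 1.8-fold higher number from compound 1 to compound 4 (0.25 log units; that floor lies within the scatter). The steps from compound 2 and from compound 3 to compound 4 cannot be read, and the ceiling now holds most of the set: the limit of > 20000 nM in this assay, at which 3 of the 4 values shown sit.

Whether compounds at this limit differ from one another remains open, since their true values are not shown. So does how an unsubstituted phenyl, or a methoxy group or a nitrile on the aryl, would read in this assay.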